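Swapping an Amino Group for Methyl: Expected Effect on Inhibition

A few compounds are considered here, and "the series" means these few. Any claim that something is new, unique, unknown or untested is made for them only; others in the source may bear on it.

Measured compounds:
Compound 1 `Cc1cnc(N)nc1-c1ccccc1` gives 34%.
Compound 2 `Cc1ncc(C)c(-c2ccccc2)n1` gives 12%.
Compound 3 `CC(C)(C)C1CCc2nc(N)ncc2C1` gives 41%.

These three compounds were tested in a functional assay on the whole organism for inhibition, with Rattus norvegicus as the target, with stated times of 1 h and 3.5 h, at a dose of 100 mg/kg by the oral route; a higher number here means more inhibition at the dose given (going by the name of the read-out), a lower number less inhibition. Compound 1 and compound 2 share one core; compound 3 has a different core, and the difference between the two cores is not broken down here. Compound 3 and compound 1 lie within the usual scatter of each other, so no order between them is claimed. Compound 2 sits lower than both.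

The change from compound 1 to compound 2 is methyl in place of amino on an aromatic carbon, and it made the step of a number 22 percentage points lower from compound 1 to compound 2 (beyond the scatter).

Compound 4 `Cc1ncc2c(n1)CCC(C(C)(C)C)C2` is not yet measured. It is made from compound 3 by methyl in place of amino on an aromatic carbon. For the measured compounds named here, this is the same kind of change as the one from compound 1 to compound 2, but the surroundings differ: in compound 3 the changed carbon is part of a fused or bridged system of two rings, meta and para to a fused ring, whereas in compound 1 it is meta to a group of 6 heavy atoms and para to a methyl group. Going by the values given here, with only one earlier example of this change, the expectation rests on that single step, due to a number 22 percentage points lower from compound 1 to compound 2 (beyond the scatter), and is therefore uncertain. The expected step is a number 22 percentage points lower from compound 3 to compound 4 (beyond the scatter). Compound 4 is estimated to give 19%, with a likely range from 5% to 35%.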

Compound 4, a percentage reported as inhibition, in the whole organism at one dose (the size of the read-out at that dose, not a potency): < 5%
Compound 4: no number, only a limit; the forecaster's own chance of this, stated with the estimate: 0%; middle value at least 14 percentage points from the limit.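

In this assay, methyl in place of amino on an aromatic carbon lowers the read-out on the second core as well, with a step of a number at least 36 percentage points lower from compound 3 to compound 4 (beyond the scatter). The direction of the change therefore carries over between these two cores, but this does not settle whether its size carries over too: the same change on two cores in this assay, a number 22 percentage points lower (beyond the scatter) from compound 1 to compound 2 and a number at least 36 percentage points lower (beyond the scatter) from compound 3 to compound 4; the limit leaves it open whether they differ. Compound 4 gives < 5%, which is a limit of the assay and not a number: the limit of < 5% in this assay, at which 1 of the 4 values shown sits.

On this carbon, between two ring nitrogen atoms, the compounds shown carry only amino or methyl, so it remains open how a hydroxyl group, a dimethylamino group or a longer chain such as ethyl would read there. Going by these compounds, with just two cores to compare, it also remains open whether the same change would lower the read-out on any further core.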